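This account rests on a few compounds, and the source may have more. Where it says the series, first, only, none or still open, it means among the compounds named here.

Working notes on the series. Of the compounds shown here, two sharing one core have been measured in a functional assay on CHO cells for antagonist activity at prostaglandin E2 receptor EP3 subtype (Homo sapiens), read by cAMP accumulation; a higher number here means a weaker inhibitor, a lower number a stronger inhibitor. Compound 1 `CC(C)C(Cc1nnc[nH]1)c1ccc(-c2ccc3cccc(F)c3c2)[nH]c1=O` gives 17 nM in this assay. Compound 2 `CC(C)C(c1noc(=O)[nH]1)c1ccc(-c2ccc3cccc(F)c3c2)[nH]c1=O` gives 41 nM in this assay. Within these two numbers compound 2 stands at the higher end, and the step of a 2.4-fold higher number from compound 1 to compound 2 (0.38 log units; beyond the scatter) is the only measured step in the set.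

The next compound, compound 3 `CC(C)C(CC(N)=O)c1ccc(-c2ccc3cccc(F)c3c2)[nH]c1=O`, carries the change (a group of 4 heavy atoms (2 carbon, 1 nitrogen, 1 oxygen; no ring) in place of a group of 6 heavy atoms (2 carbon, 2 nitrogen, 2 oxygen; one five-membered aromatic ring with 3 hetero atoms), on a saturated chain carbon bound to an aromatic carbon and a saturated chain carbon). Among the compounds with values here, no measured step removes the five-membered aromatic ring with 3 hetero atoms altogether; the one step available, a 2.4-fold higher number from compound 1 to compound 2 (0.38 log units; beyond the scatter), only exchanges one such ring for another and bears on the present change only loosely. A change of this kind, in which a ring is replaced by an open chain, is therefore read with caution, and the direction is taken from the only movement seen so far, which pointed toward higher numbers.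

The expectation for compound 3 is a step of a 3.7-fold higher number from compound 2 to compound 3 (0.56 log units; beyond the scatter), toward a higher number in this assay. The estimate for compound 3 is 150 nM, with a range from 40 nM to 600 nM.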

Compound 3, half-maximal inhibitory concentration: 53 nM
Compound 3: the middle estimate sits 2.8-fold (0.45 log units) above what was measured, and the stated range covers the measured number.
By their numbers in this assay, from the lowest: compound 1; then compounds 2 and 3 (each within the scatter of the next).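

In this assay, the carbamoylmethyl group with no ring gives a 1.3-fold higher number from compound 2 to compound 3 (0.11 log units; within the scatter), so on this saturated chain carbon a five-membered aromatic ring with 3 hetero atoms is not needed to stay within the scatter of compound 2. The comparison with the 4H-1,2,4-triazol-3-yl group gives a different reading: carbamoyl in its place on the same chain gives a 3.1-fold higher number from compound 1 to compound 3 (0.49 log units; beyond the scatter), beyond the scatter, and with the step to compound 2 also beyond it, compound 1 is now the strongest inhibitor of the three. Nothing at hand speaks to the reason for this difference between the two ring-bearing compounds and the open chain.

The compounds shown leave open whether a carboxylic acid, an amine or a longer chain ending in carbamoyl on this carbon would stay with compound 3 or move toward compound 1. They also leave open how much of the gap between compound 1 and compound 2 belongs to the ring itself and how much to its distance from the saturated chain carbon, since the two rings are not compared on the same link.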